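Dropping a Chloro Group from a Benzoyl Amide

A few compounds are considered here, and "the series" means these few. Any claim that something is new, unique, unknown or untested is made for them only; others in the source may bear on it.

Of the compounds shown here, two have been measured in a functional assay on ACHN cells (Homo sapiens) for cytotoxicity, read by sulforhodamine B assay, with a stated time of 72 h; on this read-out lower numbers stand for stronger inhibition of growth and higher numbers for weaker inhibition of growth. Compound 1, `O=C(Nc1ccccc1)C1CCc2ccccc2N1`, is the simpler of the two, and in this assay compound 1 gives 72900 nM. Compound 2, `O=C(Nc1cc(C(F)(F)F)cc(C(F)(F)F)c1)C1CCc2ccccc2N1C(=O)c1ccc(Cl)cc1`, carries more groups on the shared core, and in this assay compound 2 gives 2570 nM, the lower of the two numbers, with the gap to compound 1 lying well beyond the usual scatter. Compound 2 is thus the stronger growth inhibitor of the pair, and it is the starting point for the next step.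

Compound 3, `O=C(Nc1cc(C(F)(F)F)cc(C(F)(F)F)c1)C1CCc2ccccc2N1C(=O)c1ccccc1`, differs from compound 2 in one place: hydrogen in place of chloro on an aromatic carbon. Among the measured compounds shown here, no measured pair in this set shows this change on its own, so its size cannot be read off directly. Only one heavy atom is removed, and the expected step from compound 2 to compound 3 is a modest weakening, a 1.8-fold higher number from compound 2 to compound 3 (0.24 log units; within the scatter), near the edge of the scatter. Compound 3 is therefore estimated at 4500 nM, with a plausible range from 1500 nM to 13000 nM.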

Compound 3, concentration for 50% growth inhibition: 2920 nM
Estimate against measurement, compound 3: 1.5-fold (0.19 log units) above; low and high end bracket the measured number.
By their numbers in this assay, from the lowest: compounds 2 and 3 (each within the scatter of the next); then compound 1.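

In this assay, the step is a 1.1-fold higher number from compound 2 to compound 3 (0.06 log units; within the scatter) when the chloro group gives way to hydrogen, so the two numbers cannot be told apart. The chloro group on this aromatic carbon, para to a large group, is therefore not needed to keep the growth inhibition seen with compound 2, and a plain benzoyl serves as well as the (4-chlorophenyl)carbonyl on this read-out. Nothing available here offers any measured explanation of why this position tolerates the change.

The compounds shown carry only chloro or hydrogen at this position, so it remains open whether a larger or quite different group there, such as a methoxy, an amine or a carboxylic acid, would also leave the number in place. From the compounds shown here alone, compound 1 differs from compound 2 and compound 3 in more than one place, so those steps cannot be read, and the separate shares of the trifluoromethyl groups and of the benzoyl amide in the gap to compound 1 stay unknown.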